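Shortening the link to the hydantoin ring and dropping its methyl

The source may report more compounds than this note shows. Statements on the series, on what has been measured and on what is new or still open speak of the compounds shown alone.

Of the compounds shown here, three sharing one core have been measured in a physicochemical assay for solubility, in phosphate buffer, measured as kinetic solubility; a lower number here means a less soluble compound, a higher number a more soluble compound. Compound 1 `CC(C)C(/C=C1\NC(=O)NC1=O)c1ccc(-c2ccc3cccc(F)c3c2)[nH]c1=O` gives 10700 nM, compound 2 `CC(C)C(CC1NC(=O)NC1=O)c1ccc(-c2ccc3cccc(F)c3c2)[nH]c1=O` gives 12300 nM, and compound 3 `CC(C)C(/C=C1/C(=O)NC(=O)N1C)c1ccc(-c2ccc3cccc(F)c3c2)[nH]c1=O` gives 34800 nM. Compound 3 stands highest of the three, with a 2.8-fold higher number from compound 2 to compound 3 (0.45 log units; beyond the scatter) and a 3.3-fold higher number from compound 1 to compound 3 (0.51 log units; beyond the scatter).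

Compound 4 `CC(C)C(c1ccc(-c2ccc3cccc(F)c3c2)[nH]c1=O)C1NC(=O)NC1=O` has not yet been measured in this assay. Relative to compound 3 the change is a group of 7 heavy atoms (3 carbon, 2 nitrogen, 2 oxygen; one five-membered non-aromatic ring with 2 hetero atoms) in place of a group of 9 heavy atoms (5 carbon, 2 nitrogen, 2 oxygen; one five-membered non-aromatic ring with 2 hetero atoms), on a saturated chain carbon bound to an aromatic carbon and a saturated chain carbon. Within the data shown here, two measured steps bear on it. Among the measured compounds shown here, the methyl on the ring nitrogen was the one change that moved the number, seen as a 3.3-fold higher number from compound 1 to compound 3 (0.51 log units; beyond the scatter); compound 4 gives that methyl up again and carries the ring with two hydrogen-bond donors. Changing the link between the core and the ring mattered little, as a 1.1-fold higher number from compound 1 to compound 2 (0.06 log units; within the scatter) shows, and compound 4 differs from compound 2 only in a shorter link. A drop back towards the numbers of compound 1 and compound 2 is therefore expected.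

For compound 4 the expected step is a 2.9-fold lower number from compound 3 to compound 4 (0.46 log units; beyond the scatter). The estimate for compound 4 is 12000 nM, with a range from 5000 nM to 30000 nM.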

Compound 4, solubility: 10600 nM
Compound 4: middle estimate off by 1.1-fold (0.05 log units), on the high side; the measured number falls inside the stated range.
By their numbers in this assay, from the lowest: compounds 4, 1 and 2 (each within the scatter of the next); then compound 3.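

In this assay, 2,5-dioxoimidazolidin-4-yl set directly on this saturated chain carbon cannot be told apart from the two longer links that also lack the ring methyl: a 1.2-fold lower number from compound 2 to compound 4 (0.06 log units; within the scatter) for the saturated link and a 1.0-fold lower number from compound 1 to compound 4 (0.00 log units; within the scatter) for the link with a double bond, so three forms of the link now sit within the scatter of one another. Among these compounds, the one new step beyond the scatter is a 3.3-fold lower number from compound 3 to compound 4 (0.52 log units; beyond the scatter), which combines a shorter link with the loss of the methyl on the ring nitrogen and leaves compound 3 as the only compound set apart from the others. No measurement shown here gives a reason for these numbers.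

The compounds shown leave open whether a methyl on the ring nitrogen would raise the number of compound 4 as well, since so far that methyl appears only on the link with a double bond. They also leave open how a carboxylic acid or an amine on this saturated chain carbon would compare with the ring.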